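A few compounds are considered here, and "the series" means these few. Any claim that something is new, unique, unknown or untested is made for them only; others in the source may bear on it.

Measured so far:

- compound 1 `CC(C)Oc1cc(-c2cncc(-c3cnn(C(C)C)c3)c2)ccc1C(N)=O`: 42 nM
- compound 2 `Cc1n[nH]c(C)c1-c1cncc(-c2ccc(C(N)=O)c(OC(C)C)c2)c1`: 14 nM
- compound 3 `Cc1c(-c2cncc(-c3ccc(C(N)=O)c(OC(C)C)c3)c2)cnn1C`: 120 nM

In an assay on cells for inhibition of MAP kinase-interacting serine/threonine-protein kinase 2 (Homo sapiens), read by mobility shift assay, with stated times of 10 min and 60 min, in the presence of a further agent that is not named here (a higher number here means a weaker inhibitor, a lower number a stronger inhibitor), compound 1 gives 42 nM, the second highest of the three numbers. Compound 2 sits at the stronger end, reached through a 3.0-fold lower number from compound 1 to compound 2 (0.48 log units; beyond the scatter), while compound 3 sits at the weaker end, reached through a 2.9-fold higher number from compound 1 to compound 3 (0.46 log units; beyond the scatter); the gap between these two ends is an 8.6-fold higher number from compound 2 to compound 3 (0.93 log units; beyond the scatter). Compound 4 `CC(C)Oc1cc(-c2cncc(-c3cnn(C4CCOC4)c3)c2)ccc1C(N)=O` differs from compound 1 in one place only: oxolan-3-yl in place of isopropyl on an aromatic nitrogen. Neither measured step tests this change directly. Both exchange the whole five-membered ring for a differently substituted one, and each moved the number by a modest amount in one direction or the other. They show only that this part of the molecule tolerates change without large swings. Among the measured compounds shown here, with no direct precedent, the expectation for compound 4 is a step within the scatter, a 1.1-fold higher number from compound 1 to compound 4 (0.03 log units; within the scatter). Compound 4 is therefore estimated at 45 nM in this assay, with a range from 15 nM to 130 nM.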

Compound 4, half-maximal inhibitory concentration: 44 nM
Compound 4: the middle estimate sits 1.0-fold (0.01 log units) above what was measured; the range from low to high includes it.
By their numbers in this assay, from the lowest: compound 2; then compounds 1 and 4 (each within the scatter of the next); then compound 3.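

In this assay, among the compounds shown here, a 1.0-fold higher number from compound 1 to compound 4 (0.02 log units; within the scatter) is the first direct test of the group on this aromatic nitrogen, since the earlier steps replaced the whole substituted five-membered ring and so changed more than this one place. Oxolan-3-yl is larger than isopropyl and brings a ring and an oxygen that can act as a hydrogen-bond acceptor, yet this exchange leaves no difference that can be read beyond the scatter. Nothing here explains why the exchange is tolerated.

Still open, on these data alone, is what a piperidin-4-yl group, with its ring amine, or a longer chain ending in a carboxylic acid would do on this nitrogen. Also open, as far as these compounds go, is whether oxolan-3-yl would be tolerated equally well with the neighbouring methyl group of compound 3 present.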